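An acetylphenyl exchange on the sulfonyl sulfur

A few compounds are considered here, and "the series" means these few. Any claim that something is new, unique, unknown or untested is made for them only; others in the source may bear on it.

- compound 1 `CC(NS(=O)(=O)c1ccc(F)cc1)C1=CC(=O)c2c(O)ccc(O)c2C1=O` gives 6410 nM
- compound 2 `CC(NS(=O)(=O)c1cccc(Br)c1)C1=CC(=O)c2c(O)ccc(O)c2C1=O` gives 6350 nM

In a functional assay on HeLa cells (Homo sapiens) for cytotoxicity, read by sulforhodamine B assay (on this read-out lower numbers stand for stronger inhibition and higher numbers for weaker inhibition), compound 2 stands at 6350 nM and sits within the scatter of compound 1, so neither compound can be ranked over the other. Compound 3 `CC(=O)c1ccc(S(=O)(=O)NC(C)C2=CC(=O)c3c(O)ccc(O)c3C2=O)cc1` has not yet been measured. The change from compound 2 is 4-acetylphenyl in place of 3-bromophenyl on a sulfonyl sulfur and amounts to 4-acetylphenyl in place of 3-bromophenyl on a sulfonyl sulfur. Within the data shown here, only one measured step bears on this, made on the same sulfonyl sulfur, and it shows a 1.0-fold lower number from compound 1 to compound 2 (0.00 log units; within the scatter) with a different pair of groups. Among the measured compounds shown here, that is thin evidence, and no measured compound carries an acetyl group. No shift beyond the scatter is therefore expected in this assay and the expected size is a 1.1-fold lower number from compound 2 to compound 3 (0.02 log units; within the scatter) for this exchange. For compound 3 the estimate is 6000 nM with an expected range from 2800 nM to 13000 nM in all.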

Compound 3, half-maximal inhibitory concentration: 5760 nM
Compound 3: the middle estimate sits 1.0-fold (0.02 log units) above what was measured, and the stated range covers the measured number.
By their numbers in this assay, from the lowest: compounds 3, 2 and 1 (each within the scatter of the next).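

In this assay, 4-acetylphenyl in place of 3-bromophenyl on the sulfonyl sulfur gives a 1.1-fold lower number from compound 2 to compound 3 (0.04 log units; within the scatter), and acetyl in place of fluoro on an aromatic carbon gives a 1.1-fold lower number from compound 1 to compound 3 (0.05 log units; within the scatter), so the three compounds still cannot be ranked. The 4-acetylphenyl group brings a hydrogen-bond acceptor and a double bond outside the aromatic ring, neither of which the 3-bromophenyl group has, and this change to the group on the sulfonyl sulfur does not move the number beyond the scatter. Nothing available explains why these exchanges leave the number within the scatter.

The compounds shown leave open whether an amine or a carboxylic acid on the aromatic ring, or a plain alkyl chain in place of that ring, would shift the number beyond the scatter. From the compounds shown here alone, all three also share one core, so what a change there would do remains open.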